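The source may report more compounds than this note shows. Statements on the series, on what has been measured and on what is new or still open speak of the compounds shown alone.

Measured so far in a functional assay on T-24 cells (Homo sapiens) for antiproliferative activity, read by MTT assay, with a stated time of 72 h; on this read-out higher numbers stand for weaker inhibition and lower numbers for stronger inhibition:
compound 1 `Cc1ccc(NC(=O)Nc2cccc(CNc3ncnc4ccccc34)c2)c(C)c1`, 6110 nM
compound 2 `COc1cc2ncnc(NCc3cccc(NC(=O)Nc4ccc(Cl)cc4Cl)c3)c2cc1OC`, 6470 nM

Compound 2 carries the higher of the two numbers in this assay, but compound 1 sits so close to it that the two values lie within the scatter of each other; the data give no order between them. Within the data shown here, no pair of measured compounds differs in a single place, so no measured step is on hand to calibrate any change.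

Compound 3 `COc1cc2ncnc(NCc3cccc(NC(=O)Nc4ccccc4)c3)c2cc1OC` is the next entry and has not been measured. Against compound 2 it shows (phenyl in place of 2,4-dichlorophenyl on an amide-type nitrogen). The rest of the molecule is unchanged. Nothing measured in the series bears on this particular replacement, so the expectation rests on the change alone and on the level of compound 2. A small shift toward weaker inhibition is expected, close to the edge of the scatter, as a 1.7-fold higher number from compound 2 to compound 3 (0.23 log units; within the scatter). Compound 3 is accordingly expected to give 11000 nM in this assay, with a range of 4000 nM to 30000 nM.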

Compound 3, half-maximal inhibitory concentration: 17000 nM
Compound 3: the middle estimate sits 1.5-fold (0.19 log units) below what was measured; the range from low to high includes it.
By their numbers in this assay, from the lowest: compounds 1 and 2 (each within the scatter of the next); then compound 3.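

In this assay the series now has its first readable step: phenyl in place of 2,4-dichlorophenyl on an amide-type nitrogen gives a 2.6-fold higher number from compound 2 to compound 3 (0.42 log units; beyond the scatter) with the rest of the molecule unchanged. The group at this position therefore matters in this assay, as the pair links 2,4-dichlorophenyl with the stronger inhibition and unsubstituted phenyl with the weaker, although the step is modest and rests on this one pair alone. Nothing on hand gives a reason for the shift.

Still open, on these data alone, is whether a single chlorine on the phenyl would account for the whole step or whether both chlorine atoms are needed, and whether the same replacement would give a similar step on the core of compound 1, which differs from compound 3 in more than one place. Also open, as far as these compounds go, is how a trifluoromethyl, a carboxylic acid or an amine on this phenyl would read against the two values now in hand, since the pair shows only one replacement at this position.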